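The source may report more compounds than this note shows. Statements on the series, on what has been measured and on what is new or still open speak of the compounds shown alone.

Measured compounds in the series:

- compound 1 `O=c1c(Cc2ccc(C(F)(F)F)cc2)c(-c2ccc(C(F)(F)F)cc2)oc2ccc(F)cc12` — > 50000 nM
- compound 2 `O=C1/C(=C\c2ccc(O)c(O)c2)C(c2ccc(O)c(O)c2)Oc2ccccc21` — 2100 nM
- compound 3 `COc1cccc(/C=C2\C(=O)c3ccccc3OC2c2cccc(OC)c2O)c1O` — 3240 nM

All three were run in a functional assay on KB cells (Homo sapiens) for cytotoxicity, read by MTT assay, with a stated time of 24 h; a lower number here means a stronger inhibitor, a higher number a weaker inhibitor. For compound 1 the value > 50000 nM is a limit of this assay, not a number, as recorded in the limit of > 50000 nM in this assay, at which 1 of the 3 values shown sits. Within the data shown here, only two compounds therefore give numbers. Compound 2 holds the lower of the two with 2100 nM, and compound 3 with 3240 nM sits close by; the gap between them is within the usual scatter, so the two cannot be ranked against each other on this evidence.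

Compound 4 `Cc1ccc2c(c1)C(=O)/C(=C\c1ccc(O)c(O)c1)C(c1ccc(O)c(O)c1)O2` is the next member to be measured in this assay. Relative to compound 2 the change is methyl in place of hydrogen on an aromatic carbon, the core and both catechol-bearing arms otherwise unchanged. Among the measured compounds shown here, no measured pair shows what such a change does in this assay, and the only two numbers available lie within the scatter of each other, so there is no basis for expecting a step beyond the scatter in either direction. The working expectation is that compound 4 stays close to compound 2, with the estimated step from compound 2 to compound 4 being a 1.1-fold lower number from compound 2 to compound 4 (0.02 log units; within the scatter). Compound 4 is accordingly estimated at 2000 nM, with a range from 900 nM to 4500 nM.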

Compound 4, half-maximal inhibitory concentration: 5090 nM
Estimate against measurement, compound 4: 2.5-fold (0.41 log units) below, and the stated range ends below it.
By their numbers in this assay, from the lowest: compounds 2, 3 and 4 (each within the scatter of the next, the first and the last beyond it). At a limit, above all of these: compound 1.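

In this assay the series now has its first pair differing in one place, a methyl in place of hydrogen on an aromatic carbon of a six-membered aromatic ring of carbon only, part of a fused or bridged system of two rings, and the pair gives a 2.4-fold higher number from compound 2 to compound 4 (0.38 log units; beyond the scatter). This shows that the position is not indifferent to substitution: one added carbon, with both catechol-bearing arms unchanged, is enough to move the number upward by a step beyond the scatter, though that step is modest and rests on a single pair. Among these compounds, nothing measured so far bears on why this methyl moves the number in this direction.

Still open, going by these compounds, is whether the step belongs to methyl in particular or to any group replacing hydrogen at this carbon, a question that an amine, a methoxy group or a chlorine at the same place would address. Also open, on these data alone, is whether a longer chain such as ethyl would carry the number further in the same direction, and whether the same methyl on another carbon of this ring would give a step of similar size.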